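Moving Two Chlorines Around a Hydrazone Ring

This account rests on a few compounds, and the source may have more. Where it says the series, first, only, none or still open, it means among the compounds named here.

Three compounds sharing a trimethoxyphenyl core were tested in a functional assay on BGC-823 cells (Homo sapiens) for antiproliferative activity, read by MTT assay, tested at 5 uM; on this read-out lower numbers stand for a weaker effect and higher numbers for a stronger effect at the one concentration tested. Compound 1 `COc1cc(C2=NN(C(C)=O)C(c3ccc(F)cc3)O2)cc(OC)c1OC` gives 13.3%, compound 2 `COc1cc(C(=O)N/N=C/c2c(Cl)cccc2Cl)cc(OC)c1OC` gives 27.8%, and compound 3 `COc1cc(C(=O)N/N=C/c2ccc(Cl)c([N+](=O)[O-])c2)cc(OC)c1OC` gives 2.3%. Compound 2 thus stands highest of the three, beyond the scatter above compound 1 and further still above compound 3.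

Compound 4 `COc1cc(C(=O)N/N=C/c2cc(Cl)cc(Cl)c2)cc(OC)c1OC` has not been measured. It differs from compound 2 in one way: 3,5-dichlorophenyl in place of 2,6-dichlorophenyl on a carbon with a double bond to nitrogen. Going by the values given here, no pair of measured compounds shows how such a rearrangement of the two chlorines plays out, so the expectation rests on compound 2 alone. A small downward step, possibly within the scatter, is expected for compound 4, with a number 8.8 percentage points lower from compound 2 to compound 4 (within the scatter), giving an estimated 19% in this assay, within a range from 5% to 35%.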

Compound 4, a percentage reported as inhibition, at one concentration (the size of the read-out at that concentration, not a potency): 9.2%
Compound 4: the middle estimate sits 9.8 percentage points above what was measured; the measured number falls inside the stated range.
By their numbers in this assay, from the lowest: compounds 3, 4 and 1 (each within the scatter of the next, the first and the last beyond it); then compound 2.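

In this assay, exchanging 2,6-dichlorophenyl for 3,5-dichlorophenyl on the carbon with a double bond to nitrogen gives a number 18.6 percentage points lower from compound 2 to compound 4 (beyond the scatter). The two compounds have the same atoms, joined differently, so at this position the arrangement of the two chlorines alone is enough to change the read-out. Nothing available here explains this drop.

Going by these compounds, whether two methyl groups arranged like either pair of chlorines would give the same contrast remains open. So does the outcome with an amine on this ring.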